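This account rests on a few compounds, and the source may have more. Where it says the series, first, only, none or still open, it means among the compounds named here.

Working notes on the series. Three compounds share the core and differ in one group on an aromatic carbon. Compound 1 `Fc1ccc(-c2nc3sc(Cc4ccc(Cl)cc4)nn3c2Br)cc1` carries fluoro there. In a functional assay on L1210 cells (Mus musculus) for cytotoxicity, with a stated time of 48 h (a lower number here means a stronger inhibitor, a higher number a weaker inhibitor), compound 1 gives only a limit, > 250000 nM. Compound 2 `Cc1ccc(-c2nc3sc(Cc4ccc(Cl)cc4)nn3c2Br)cc1` carries methyl in its place; in this assay compound 2 likewise gives only a limit, > 250000 nM. For the measured compounds named here, compound 3 `O=[N+]([O-])c1ccc(-c2nc3sc(Cc4ccc(Cl)cc4)nn3c2Br)cc1` carries nitro; in this assay compound 3 gives 94000 nM, the only actual number in the set, the other two values sitting at the limit of > 250000 nM in this assay, at which 2 of the 3 values shown sit. The step of an at least 2.6-fold lower number from compound 1 to compound 3 (0.42 log units; beyond the scatter) and the step of an at least 2.6-fold lower number from compound 2 to compound 3 (0.42 log units; beyond the scatter) are read against those limits, so only their lower bound is known; the step that the two limits leave unreadable from compound 1 to compound 2 cannot be read at all.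

Compound 4 `O=Cc1c(-c2ccc([N+](=O)[O-])cc2)nc2sc(Cc3ccc(Cl)cc3)nn12` keeps the nitro group and alters the shared core: formyl in place of bromo on an aromatic carbon. Going by the values given here, none of the measured steps touches this part of the core; all of them vary the group on the other aromatic carbon. Among the compounds with values here, no measured step therefore bears on the change from compound 3 to compound 4, and neither direction nor size can be taken from the set. The expectation for compound 4 in this assay is a step of no change at the digits printed from compound 3 to compound 4 (within the scatter). Compound 4 is estimated at 94000 nM, with a range from 25000 nM to 250000 nM.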

Compound 4, half-maximal inhibitory concentration: 15000 nM
For compound 4 the middle estimate is 6.3-fold (0.80 log units) above the measured one; measured number outside the range, below it.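

In this assay, for the compounds shown here, replacing bromo with formyl on the aromatic carbon of the five-membered aromatic ring with 2 nitrogen gives a 6.3-fold lower number from compound 3 to compound 4 (0.80 log units; beyond the scatter), so this position of the shared core can move the read-out, which the earlier steps could not show as they all varied the group on the other aromatic carbon. Going by these compounds alone, this is also the first step with an actual number at both ends, so its size is known and not just a lower bound. Nothing measured in the set speaks to the reason for this step.

The compounds shown leave open whether formyl in place of bromo gives a similar step with fluoro or methyl on the other aromatic carbon, since this change is seen only with nitro there. They also leave open how this position responds to other groups, such as a carboxylic acid, an amine or a hydroxymethyl group, and so whether formyl itself matters or bromo is simply a poor group at this place.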